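The source may report more compounds than this note shows. Statements on the series, on what has been measured and on what is new or still open speak of the compounds shown alone.

Of the compounds shown here, three of this set have been measured in a functional assay on L1210 cells (Mus musculus) for inhibition; on this read-out higher numbers stand for weaker inhibition and lower numbers for stronger inhibition. Compound 1 `C=CCn1cc(C(N)=S)c2c(N)ncnc21` gives 38000 nM. Compound 3 `Cn1cc(C(=N)S)c2c(N)ncnc21` gives 38000 nM. Compound 2 `NC(=S)c1cn(COCc2ccccc2)c2ncnc(N)c12` gives 100000 nM, the highest of the three numbers, and its gap to both compound 1 and compound 3 lies beyond the usual scatter, so it is the weakest inhibitor among the measured compounds.

The step from compound 2 leads to compound 4 `NC(=O)c1cn(COCc2ccccc2)c2ncnc(N)c12`, which differs from compound 2 in a single place: a group of 3 heavy atoms (1 carbon, 1 nitrogen, 1 oxygen; no ring) in place of a group of 3 heavy atoms (1 carbon, 1 nitrogen, 1 sulfur; no ring), on an aromatic carbon. No comparable exchange exists among the measured compounds, so there is nothing to show what this change does here, and no direction can be read from the data.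

The step of a 1.1-fold lower number from compound 2 to compound 4 (0.05 log units; within the scatter) is therefore expected to be small, with no change beyond the scatter. In this assay compound 4 is estimated at 90000 nM, with a plausible range from 30000 nM to 300000 nM.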

Compound 4, half-maximal inhibitory concentration: 70000 nM
The estimate for compound 4 lay 1.3-fold (0.11 log units) above the measured number; measured number inside the range.
By their numbers in this assay, from the lowest: compounds 1, 3, 4 and 2 (each within the scatter of the next, the first and the last beyond it).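

In this assay the exchange of the sulfur-containing group for carbamoyl, on an aromatic carbon of the five-membered ring, gives a 1.4-fold lower number from compound 2 to compound 4 (0.15 log units; within the scatter) and so stays within the scatter. Among the compounds shown here, this is the first direct reading at this position, as the earlier compounds offered no pair differing in one place, and it shows that, with the rest of the molecule held the same, replacing sulfur with oxygen in this group of 3 heavy atoms leaves the read-out essentially unmoved. Nothing available explains this result.

As far as these compounds go, whether a nitrile, a carboxylic acid or a methyl ester on the same aromatic carbon would also stay within the scatter remains open. So does whether the sulfur-to-oxygen exchange gives a similar step when a methyl or another group replaces the other substituent shared by compound 2 and compound 4.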